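Methylsulfonyl in place of hydrogen on a shared core

The source may report more compounds than this note shows. Statements on the series, on what has been measured and on what is new or still open speak of the compounds shown alone.

Compound 1, `CC#C[C@H](CC(=O)O)c1ccc(OC[C@H]2COc3ccc(Cl)cc3O2)cc1`: 47%
Compound 2, `CC#C[C@@H](CC(=O)O)c1ccc(OC[C@H]2COc3cccc(Cl)c3O2)cc1`: 95%
Compound 3, `CC#C[C@@H](CC(=O)O)c1ccc(OC[C@H]2COc3ccccc3O2)cc1`: 70%

In a functional assay on HEK293 cells for agonist activity at Free fatty acid receptor 1 (Homo sapiens), read by fluorescence and calcium flux, with a stated time of 10 min (a higher number here means a larger maximal response, a lower number a smaller maximal response), compound 3 stands second highest of the three, with compound 2 above and compound 1 below it. Compound 4, `CC#C[C@@H](CC(=O)O)c1ccc(OC[C@H]2COc3ccc(S(C)(=O)=O)cc3O2)cc1`, has not been measured; it differs from compound 3 by methylsulfonyl in place of hydrogen on an aromatic carbon. Going by the values given here, the only measured single change is a number 25 percentage points lower from compound 2 to compound 3 (beyond the scatter), a chloro removed from a different position, so it bears only loosely on this step. Among the compounds with values here, no measured compound carries a methylsulfonyl group. A group entering at this position is therefore expected to shift the value modestly upward, estimated as a number 8 percentage points higher from compound 3 to compound 4 (within the scatter). Compound 4 is expected to reach 78%, within 50% to 105%.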

Compound 4, largest response reached (Emax), in percent of the reference or control that the assay uses: 55%
Compound 4: middle estimate off by 23 percentage points, on the high side; measured number inside the range.
By their numbers in this assay, from the lowest: compounds 1 and 4 (each within the scatter of the next); then compound 3; then compound 2.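

In this assay there is a number 15 percentage points lower from compound 3 to compound 4 (beyond the scatter) when methylsulfonyl replaces hydrogen on this aromatic carbon. Going by these compounds alone, this is the first measured change in which adding a group to this ring goes with a smaller maximal response. The earlier step ran the other way, with a number 25 percentage points lower from compound 2 to compound 3 (beyond the scatter) when a chloro at a different position gave way to hydrogen, so adding a group does not raise the response everywhere on this ring.

Going by these compounds, whether methoxy or an amine at this position would also lower the response remains open. Nothing measured here gives a reason for the drop with methylsulfonyl.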